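This account rests on a few compounds, and the source may have more. Where it says the series, first, only, none or still open, it means among the compounds named here.

Measured so far, in an assay on isolated protein for inhibition of Long-chain-fatty-acid--CoA ligase 1 (Homo sapiens), read by mass spectrometry, with a stated time of 90 min, in the presence of a further agent that is not named here; a higher number here means a weaker inhibitor, a lower number a stronger inhibitor:

Compound 1, `Cc1ccccc1Cc1nc2cc(O[C@H]3CC[C@@H](C(=O)O)CC3)ccc2n1C`, gives 7800 nM.
Compound 2, `Cc1ccc(Cc2nc3cc(O[C@H]4CC[C@@H](C(=O)O)CC4)ccc3n2C)cc1`, gives 150 nM.

Among the measured compounds shown here, compound 2 holds the lowest of the two numbers; the only other compound, compound 1, sits a long way above it, and the step of a 52-fold lower number from compound 1 to compound 2 (1.72 log units; beyond the scatter) is large and beyond the scatter. Compound 3, `Cn1c(Cc2cccc(C(F)(F)F)c2)nc2cc(O[C@H]3CC[C@@H](C(=O)O)CC3)ccc21`, has not yet been measured in this assay. It differs from compound 2 by 3-(trifluoromethyl)phenyl in place of 4-methylphenyl on a saturated chain carbon bound to an aromatic carbon. For the measured compounds named here, the one measured step that bears on this change is the one at the same place, a 52-fold lower number from compound 1 to compound 2 (1.72 log units; beyond the scatter), which shows that the pattern on this ring matters strongly here, yet neither compound carries a substituent at the position now occupied. The estimate for compound 3 is therefore uncertain: the expected step of a 4.0-fold higher number from compound 2 to compound 3 (0.60 log units; beyond the scatter) is a moderate rise, and compound 3 is estimated at 600 nM, within a range of 100 nM to 4000 nM.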

Compound 3, half-maximal inhibitory concentration: 190 nM
Compound 3: middle estimate off by 3.2-fold (0.50 log units), on the high side; low and high end bracket the measured number.
By their numbers in this assay, from the lowest: compounds 2 and 3 (each within the scatter of the next); then compound 1.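

In this assay, replacing 4-methylphenyl with 3-(trifluoromethyl)phenyl on the saturated chain carbon bound to an aromatic carbon gives a 1.3-fold higher number from compound 2 to compound 3 (0.10 log units; within the scatter), so this position accepts a substituted phenyl other than 4-methylphenyl without a change that can be read. Among the compounds shown here, replacing 2-methylphenyl with the same group gives a 41-fold lower number from compound 1 to compound 3 (1.61 log units; beyond the scatter), which shows that the low number seen with compound 2 is not unique to 4-methylphenyl and leaves 2-methylphenyl as the one group of the three that stands apart. No measurement here offers an explanation for these results.

The step from compound 2 to compound 3 changes both the substituent and its place on the ring, so the share of each cannot be separated. As far as these compounds go, whether a methoxy group, a chlorine atom or an amine on this ring would fit as well remains open.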